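From cyclopentyl ether to fluorobenzoate ester on the shared core

This account rests on a few compounds, and the source may have more. Where it says the series, first, only, none or still open, it means among the compounds named here.

compound 1 `Cc1nn(-c2ncnc3nc[nH]c23)c2c1C(OC1CCCC1)CC(=O)N2` — 62 nM
compound 2 `Cc1nn(-c2ncnc3nc[nH]c23)c2c1C(OCc1ccc(C(C)C)cc1)CC(=O)N2` — 1690 nM
compound 3 `Cc1nn(-c2ncnc3nc[nH]c23)c2c1C(NC(=O)c1ccccc1)CC(=O)N2` — 158 nM

In a functional assay on HEK293 cells for agonist activity at G-protein coupled receptor 39 (Homo sapiens), read by scintillation proximity assay and inositol phosphate accumulation, with a stated time of 75 min (on this read-out lower numbers stand for an effect already at smaller amounts and higher numbers for an effect only at larger amounts of compound), compound 1 gives 62 nM, the lowest of the three numbers; compound 3 stands nearest and compound 2 furthest. Compound 4 `Cc1nn(-c2ncnc3nc[nH]c23)c2c1C(OC(=O)c1ccc(F)cc1)CC(=O)N2` differs from compound 1 in one place: (4-fluorophenyl)carbonyl in place of cyclopentyl on an oxygen on a saturated carbon. Among the compounds with values here, two measured steps bear on this. Putting 4-isopropylbenzyl in place of cyclopentyl on the same oxygen gave a 27-fold higher number from compound 1 to compound 2 (1.44 log units; beyond the scatter), whereas benzamido in place of cyclopentyloxy gave a 2.5-fold higher number from compound 1 to compound 3 (0.41 log units; beyond the scatter). The entering group pairs an aromatic ring with a carbonyl, as the benzamido of compound 3 does, so a rise of intermediate size is expected, a 4.8-fold higher number from compound 1 to compound 4 (0.68 log units; beyond the scatter). Compound 4 is therefore estimated at 300 nM, with a range from 80 nM to 1500 nM.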

Compound 4, half-maximal effective concentration: 245 nM
Compound 4: middle estimate off by 1.2-fold (0.09 log units), on the high side, within the range that was stated.
By their numbers in this assay, from the lowest: compound 1; then compounds 3 and 4 (each within the scatter of the next); then compound 2.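

On the oxygen, (4-fluorophenyl)carbonyl gives a 6.9-fold lower number from compound 2 to compound 4 (0.84 log units; beyond the scatter), yet against cyclopentyl it gives a 4.0-fold higher number from compound 1 to compound 4 (0.60 log units; beyond the scatter). Both aromatic groups on this oxygen therefore give higher numbers than cyclopentyl, but the size of the rise depends on which one enters. Exchanging benzamido for ((4-fluorophenyl)carbonyl)oxy on the saturated ring carbon gives a 1.6-fold higher number from compound 3 to compound 4 (0.19 log units; within the scatter), so these two groups are not told apart here. Nothing available explains these differences. As far as these compounds go, whether a cyclohexyl ring, a straight butyl chain or an amine on this position would match or better compound 1 stays open.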